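The source may report more compounds than this note shows. Statements on the series, on what has been measured and on what is new or still open speak of the compounds shown alone.

Measured compounds:
compound 1, `COc1c(OCCCCNCc2ccccc2)cc(O)c2c(=O)cc(-c3ccccc3)oc12`: 4590 nM
compound 2, `COc1c(OCCCN2CCCC2)cc(O)c2c(=O)cc(-c3ccccc3)oc12`: 1390 nM
compound 3, `COc1c(OCc2ncc(C)o2)cc(O)c2c(=O)cc(-c3ccccc3)oc12`: > 100000 nM

In a functional assay on A549 cells (Homo sapiens) for cytotoxicity, read by MTT assay, with a stated time of 48 h (on this read-out higher numbers stand for weaker inhibition and lower numbers for stronger inhibition), compound 1 gives 4590 nM and compound 2 gives 1390 nM. For compound 3 only a limit of the assay is known, > 100000 nM, and no number stands for it. Compound 3 therefore stands at the weak end of the three. The step of an at least 21-fold higher number from compound 1 to compound 3 (1.33 log units; beyond the scatter) is large, and so is the step of an at least 71-fold higher number from compound 2 to compound 3 (1.85 log units; beyond the scatter); both run toward compound 3 and both exchange a chain bearing a nitrogen for the 5-methyl-1,3-oxazol-2-yl group.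

Compound 4, `COc1c(OCCCCN2CCN(C)CC2)cc(O)c2c(=O)cc(-c3ccccc3)oc12`, has not yet been measured. It differs from compound 3 in one place: 3-(4-methylpiperazin-1-yl)propyl in place of 5-methyl-1,3-oxazol-2-yl on a saturated chain carbon bound to an oxygen on an aromatic ring. This reverses the kind of change seen in those two steps, bringing back a chain that carries a non-aromatic ring with nitrogen, as compound 2 does. The two large steps above are the ones that bear on it, and a large step in the opposite direction is expected, that is toward a lower number. The expected step is an at least 40-fold lower number from compound 3 to compound 4 (1.60 log units; beyond the scatter). Compound 4 is estimated at 2500 nM, with a range from 700 nM to 9000 nM.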

Compound 4, half-maximal inhibitory concentration: 1500 nM
Compound 4: middle estimate off by 1.7-fold (0.22 log units), on the high side; the range from low to high includes it.
By their numbers in this assay, from the lowest: compounds 2 and 4 (each within the scatter of the next); then compound 1. At a limit, above all of these: compound 3.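

In this assay, 3-(4-methylpiperazin-1-yl)propyl in place of 5-methyl-1,3-oxazol-2-yl gives an at least 66-fold lower number from compound 3 to compound 4 (1.82 log units; beyond the scatter), which shows that this place on the oxygen can recover from the limit, though the true size of the step stays unknown since it starts from a limit of the assay for compound 3 and not from a number: the limit of > 100000 nM in this assay, at which 1 of the 4 values shown sits.
The end of the chain matters less among the two ring amines, as (4-methylpiperazin-1-yl)methyl in place of pyrrolidin-1-yl gives a 1.1-fold higher number from compound 2 to compound 4 (0.03 log units; within the scatter). Against the open benzylamino end, 4-methylpiperazin-1-yl gives a 3.1-fold lower number from compound 1 to compound 4 (0.49 log units; beyond the scatter), so a modest difference does appear there.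

Compound 3 differs from the others in both its aromatic ring and the length of its link, so the role of the chain nitrogen remains unsettled. A plain butyl chain or a morpholin-4-yl group on the same chain would help separate these features.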